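Hexyl for pyridin-2-yl on a triple-bonded carbon

This account rests on a few compounds, and the source may have more. Where it says the series, first, only, none or still open, it means among the compounds named here.

In a functional assay on NIH3T3 cells (Mus musculus) (a lower number here means that less compound is needed, a higher number that more compound is needed for the effect), compound 1 (`Cn1cncc1C(OCc1ccc(C#N)cc1C#Cc1ccccn1)c1ccc(C#N)cc1`) gives > 0.1 nM, which is a limit and not a number. Among the compounds with values here, compound 2 (`Cn1cncc1C(OCc1ccc(C#N)cc1/C=C/c1ccccn1)c1ccc(C#N)cc1`) gives 23.1 nM, the only true number so far. Within the data shown here, the one measured step, a step that the limit leaves unreadable from compound 1 to compound 2, exchanges 2-(pyridin-2-yl)ethynyl for 2-(pyridin-2-yl)ethenyl, and its size cannot be read.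

Compound 3 (`CCCCCCC#Cc1cc(C#N)ccc1COC(c1ccc(C#N)cc1)c1cncn1C`) changes compound 1 further out on the same chain: hexyl in place of pyridin-2-yl on a triple-bonded carbon. Among the measured compounds shown here, no measured step covers this exchange, so neither its size nor its direction is fixed by the data. The only anchor for the scale of this assay is compound 2 at 23.1 nM, and a wide range is therefore kept. The expected step is a step that the limit leaves unreadable from compound 1 to compound 3, with its direction left open. For compound 3 the estimated value is 20 nM, with an expected range of 3 nM to 150 nM.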

Compound 3, half-maximal effective concentration: > 0.1 nM
Compound 3 ended at the assay's limit; the forecaster's own chance of this, stated with the estimate: 15%; the middle value is on the limit's open side.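

Within the data shown here, no step from compound 1 or compound 2 to compound 3 can be read in this assay, as compound 3 ends at a limit and not at a number: the limit of > 0.1 nM in this assay, at which 2 of the 3 values shown sit.

The compounds shown leave open the true values of compound 1 and compound 3, and so whether hexyl or pyridin-2-yl on a triple-bonded carbon needs less compound for the effect.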